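Compound 3 to Compound 4: A Ring Group Gives Way

The source may hold more compounds than are shown below. What is called first, only, known or untested is meant among the compounds shown, and "the series" means these compounds.

Three related compounds share one core and differ in the group on a saturated chain carbon bound to an aromatic carbon. In a functional assay on Huh-7 cells (Homo sapiens) for cytotoxicity, read by MTT assay, with a stated time of 3 days (on this read-out lower numbers stand for higher toxicity in this test and higher numbers for lower toxicity in this test), compound 1 `OC[C@H]1O[C@@H](n2cnc3c(CSCc4ccccc4)ncnc32)[C@H](O)[C@@H]1O` gives > 100000 nM, which is a limit. Compound 2 `O=c1ccn(Cc2ncnc3c2ncn3[C@@H]2O[C@H](CO)[C@@H](O)[C@H]2O)cc1` gives > 100000 nM, also a limit. Compound 3 `OC[C@H]1O[C@@H](n2cnc3c(COc4ccccn4)ncnc32)[C@H](O)[C@@H]1O` gives > 250000 nM, again a limit and not a number. Compound 4 `O=C(O)CNCc1ncnc2c1ncn2[C@@H]1O[C@H](CO)[C@@H](O)[C@H]1O` carries (carboxymethyl)amino in place of (pyridin-2-yl)oxy ((carboxymethyl)amino in place of (pyridin-2-yl)oxy on a saturated chain carbon bound to an aromatic carbon). The measured steps a step that the two limits leave unreadable from compound 1 to compound 3, a step that the two limits leave unreadable from compound 2 to compound 3 and a step that the two limits leave unreadable from compound 1 to compound 2 have no readable size, so none of these groups gives a measured toxicity. The expected a number no higher from compound 3 to compound 4 (the limit leaves the size open) is therefore nothing beyond the usual scatter. For compound 4 the estimate is 250000 nM, with an expected range from 100000 nM to 500000 nM.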

Compound 4, half-maximal cytotoxic concentration: > 100000 nM
Compound 4: no number, only a limit; the forecaster's own chance of this, stated with the estimate: 90%; the middle value lies beyond the limit too.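

Compound 4, like compound 1, compound 2 and compound 3, gives only a limit and not a number, and no step among these compounds can be read. As far as these compounds go, whether their toxicity differs at all in this assay stays open.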